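A Longer Unsaturated Ester on the Polar Analogue

The compounds below may be only part of what the source reports. "The series", "measured", "known", "first", "only" and "open" are said of these compounds alone.

Compound 3 `COC(=O)/C=C(C)/C=C/CC(C)CCCC(C)(C)OC` stands lowest of the three numbers in a physicochemical assay for lipophilicity (a lower number here means a more polar compound, a higher number a more lipophilic compound), giving 5. Its nearest neighbour is compound 1 `COC(=O)/C=C(C)/C=C/CC(C)CCCC(C)C`, which gives 6.2 in this assay; the furthest is compound 2 `C=CCOC(=O)/C=C(C)/C=C/CC(C)CCCC(C)C`, which gives 6.73. The gap to compound 1 is the step of a number 1.20 log units lower from compound 1 to compound 3 (beyond the scatter), and the gap to compound 2 adds to that the step of a number 0.53 log units higher from compound 1 to compound 2 (beyond the scatter).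

Compound 4 `C/C=C/COC(=O)/C=C(C)/C=C/CC(C)CCCC(C)(C)OC` differs from compound 3 in one place: prop-1-en-1-yl in place of hydrogen on a saturated chain carbon bound to an oxygen next to a carbonyl group.

Within the data shown here, only one measured step bears on this change, a number 0.53 log units higher from compound 1 to compound 2 (beyond the scatter), in which vinyl entered at the same place, on a saturated chain carbon bound to an oxygen next to a carbonyl group. Among the measured compounds shown here, compound 4 instead receives prop-1-en-1-yl there, a group that carries more of what is counted above than vinyl does, so a rise in this assay somewhat larger than that step is expected, with no measured example of this exact group to sharpen the guess. Compound 4 is therefore expected to give 5.9 in this assay, with a plausible range from 5.4 to 6.4. This corresponds to an expected step of a number 0.90 log units higher from compound 3 to compound 4 (beyond the scatter).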

Compound 4, partition coefficient: 6.07
Estimate against measurement, compound 4: 0.17 log units below, within the range that was stated.
By their numbers in this assay, from the lowest: compound 3; then compounds 4 and 1 (each within the scatter of the next); then compound 2.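

In this assay, the change at this position gives a number 1.07 log units higher from compound 3 to compound 4 (beyond the scatter) when prop-1-en-1-yl replaces hydrogen on a saturated chain carbon bound to an oxygen next to a carbonyl group. Among these compounds, the only earlier step at this place was a number 0.53 log units higher from compound 1 to compound 2 (beyond the scatter) with vinyl, on a chain without the methoxy group, and a rise at this place is now seen both with and without that methoxy group. The two steps differ in the entering group as well as in the rest of the molecule, which leaves their sizes without a clean comparison, and nothing shown accounts for either rise.

Left open is how prop-1-en-1-yl and vinyl would compare on one and the same core, and whether a saturated chain such as propyl would give a rise of similar size at this place. Also open, from the compounds shown here alone, is what a free carboxylic acid or an amide in place of the ester would do to the number in this assay on either the methoxy-bearing core or the core of compound 1.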